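The source may report more compounds than this note shows. Statements on the series, on what has been measured and on what is new or still open speak of the compounds shown alone.

Measured so far:
- compound 1 `CC(C)c1ccc(NC(=O)N2CCN(c3ncccc3[N+](=O)[O-])CC2)cc1` — 245 nM
- compound 2 `CC(C)c1ccc(NC(=O)N2CCN(c3ncccc3Br)CC2)cc1` — 27.1 nM
- compound 3 `O=C(Nc1ccc(Br)cc1)N1CCN(c2ncccc2Cl)CC1` — 1010 nM

Values come from a functional assay on HEK293 cells for antagonist activity at transient receptor potential cation channel subfamily V member 1 (Rattus norvegicus); a higher number here means a weaker inhibitor, a lower number a stronger inhibitor. Compound 2 gives 27.1 nM and compound 1 gives 245 nM; the step of a 9.0-fold higher number from compound 2 to compound 1 (0.96 log units; beyond the scatter) goes with nitro in place of bromo on an aromatic carbon. Compound 3 gives 1010 nM, the highest of the three numbers; the difference between its core and that of compound 2 is not broken down here.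

Compound 4 `O=C(Nc1ccc([N+](=O)[O-])cc1)N1CCN(c2ncccc2Cl)CC1` is not yet measured. It differs from compound 3 by nitro in place of bromo on an aromatic carbon. This is the same kind of change as from compound 2 to compound 1, not the same: there the place was on a six-membered aromatic ring with one nitrogen, ortto a large group and two atoms from the ring nitrogen, whereas here it is on a six-membered aromatic ring of carbon only, para to a large group. Among the measured compounds shown here, because the one recorded instance of the change reads a 9.0-fold higher number from compound 2 to compound 1 (0.96 log units; beyond the scatter), a higher number is expected for compound 4 in this assay, though a smaller step is assumed given the different surroundings. The expected step is a 2.8-fold higher number from compound 3 to compound 4 (0.44 log units; beyond the scatter). The estimate for compound 4 is 2800 nM, expected between 900 nM and 9000 nM.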

Compound 4, half-maximal inhibitory concentration: > 25000 nM
Compound 4: no number, only a limit; the forecaster's own chance of this, stated with the estimate: 15%; middle value at least 8.9-fold (0.95 log units) away from the limit.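

The new step is an at least 24-fold higher number from compound 3 to compound 4 (1.39 log units; beyond the scatter), with nitro in place of bromo on an aromatic carbon; in this assay its direction matches the earlier step on the other core, but its size does not carry over: the same change on two cores in this assay, a 9.0-fold higher number (0.96 log units; beyond the scatter) from compound 2 to compound 1 and an at least 24-fold higher number (1.39 log units; beyond the scatter) from compound 3 to compound 4, at least 2.7-fold (0.43 log units) apart, beyond the scatter of two such steps

Compound 4 stands at > 25000 nM, which is a limit of the assay and not a number.

Going by these compounds, the full size of this step therefore stays unknown, and two pairs cannot show whether the gap between the steps goes with the place of the change, on a ring of carbon only rather than a ring with one nitrogen, or with other differences between the cores.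

Open, on these data alone, is how an amine, a nitrile or a carboxylic acid in place of bromo, para to a large group on the core of compound 3, would read against nitro. Also open, as far as these compounds go, is whether any such exchange would give steps of similar size on the core of compound 2.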